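Adding a Dichlorophenyl Group: Expected Effect on Cell Toxicity

This account rests on a few compounds, and the source may have more. Where it says the series, first, only, none or still open, it means among the compounds named here.

Measured so far:
compound 1, `CCOC(=O)c1cc2ccc(OCCCn3cc(CNC(=O)CCCCC4CCSS4)nn3)cc2oc1=O`: 36.1%
compound 2, `O=C(CCCCC1CCSS1)NCc1cn(CCCCOc2ccc3ccc(=O)oc3c2)nn1`: 65.1%

Of the compounds shown here, two have been measured in a functional assay on PC-12 cells (Rattus norvegicus) for cytotoxicity, read by MTT assay, with stated times of 3 h and 2 h, tested at 10 uM; on this read-out lower numbers stand for a weaker effect and higher numbers for a stronger effect at the one concentration tested. Compound 1 `CCOC(=O)c1cc2ccc(OCCCn3cc(CNC(=O)CCCCC4CCSS4)nn3)cc2oc1=O` gives 36.1%, while compound 2 `O=C(CCCCC1CCSS1)NCc1cn(CCCCOc2ccc3ccc(=O)oc3c2)nn1` gives 65.1%, the higher of the two numbers by a margin beyond the usual scatter. Among the compounds with values here, no pair of measured compounds differs in only one place, so the data offer no direct guide to how a single substitution shifts this read-out.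

Compound 3 `O=C(CCCCC1CCSS1)NCc1cn(CCCCOc2ccc3cc(-c4ccc(Cl)c(Cl)c4)c(=O)oc3c2)nn1` differs from compound 2 by one change: 3,4-dichlorophenyl in place of hydrogen on an aromatic carbon. Within the data shown here, nothing among the measured compounds resembles this change, so its direction in this assay cannot be read from the data; the step is expected to be small, within the scatter or just beyond it, at a number 3.1 percentage points lower from compound 2 to compound 3 (within the scatter). Compound 3 is therefore expected to give about 62%, with a range from 35% to 85%.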

Compound 3, a percentage reported as activity, at one concentration (the size of the read-out at that concentration, not a potency): 58.9%
For compound 3 the middle estimate is 3.1 percentage points above the measured one; the range from low to high includes it.
By their numbers in this assay, from the lowest: compound 1; then compounds 3 and 2 (each within the scatter of the next).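

In this assay, putting 3,4-dichlorophenyl in place of hydrogen on this aromatic carbon, two atoms from the ring oxygen, gives a number 6.2 percentage points lower from compound 2 to compound 3 (within the scatter). This position can therefore carry an added aromatic ring of 8 heavy atoms, including 2 chlorine atoms, with no change in the read-out that stands clear of the usual scatter at the one concentration tested. Nothing available explains why the read-out holds at this position.

Still open, as far as these compounds go, is whether other groups at this position, such as an amine, a carboxylic acid or a plain phenyl ring, would also stay within the scatter. From the compounds shown here alone, it is also open whether this single step would look the same at other concentrations or with the same group on a different core.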